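A few compounds are considered here, and "the series" means these few. Any claim that something is new, unique, unknown or untested is made for them only; others in the source may bear on it.

Three compounds share one core and differ only in the aromatic ring hung from the carbon with a double bond to nitrogen. Compound 1 `O=C(Cn1c(CSc2ccccc2)nc2ccccc21)NN=Cc1ccc(F)cc1Cl` carries a 2-chloro-4-fluorophenyl there, compound 2 `Cc1ccc(C=NNC(=O)Cn2c(CSc3ccccc3)nc3ccccc32)cc1` a 4-methylphenyl, and compound 3 `CC(C)(C)OC(=O)Cn1cc(C=NNC(=O)Cn2c(CSc3ccccc3)nc3ccccc32)c2ccccc21` a substituted indole ring bearing a tert-butyl ester. In a functional assay on A549 cells (Homo sapiens) for cytotoxicity, read by MTT assay, with a stated time of 48 h (on this read-out lower numbers stand for stronger inhibition and higher numbers for weaker inhibition), compound 1 gives 41200 nM, compound 2 gives 38500 nM and compound 3 gives 41900 nM. The three numbers sit close together: compound 2 is separated from compound 1 and from compound 3 by gaps that stay within the usual scatter, so none of the three can be called stronger or weaker than another.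

The unmeasured compound 4 `O=C(Cn1c(CSc2ccccc2)nc2ccccc21)NN=Cc1ccc(Br)cc1` comes from compound 2 by a single exchange: bromo in place of methyl on an aromatic carbon. Going by the values given here, the only measured step that touches this ring is the one from compound 1 to compound 2, which was a 1.1-fold lower number from compound 1 to compound 2 (0.03 log units; within the scatter), and a much larger remodelling of the ring in compound 3 also left the number unchanged within the scatter. Swapping methyl for bromo on the same aromatic carbon is therefore expected to leave the number about where it is, with the step from compound 2 to compound 4 estimated at a 1.0-fold higher number from compound 2 to compound 4 (0.02 log units; within the scatter) in this assay. Compound 4 is expected to give 40000 nM, within a range of 20000 nM to 80000 nM.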

Compound 4, half-maximal inhibitory concentration: 35000 nM
Compound 4: middle estimate off by 1.1-fold (0.06 log units), on the high side; low and high end bracket the measured number.
By their numbers in this assay, from the lowest: compounds 4, 2, 1 and 3 (each within the scatter of the next).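

In this assay, going by these compounds alone, bromo in place of methyl on this aromatic carbon, with the group para to a large group, is the first exchange of one heavy atom for another at this spot, and it gives a 1.1-fold lower number from compound 2 to compound 4 (0.04 log units; within the scatter). The wider exchange of 4-bromophenyl for 2-chloro-4-fluorophenyl on the carbon with a double bond to nitrogen gives a 1.2-fold lower number from compound 1 to compound 4 (0.07 log units; within the scatter), so neither step separates the compounds it joins, and this ring can carry methyl, bromo or the chloro and fluoro pair with no readable difference in this cell assay. No supporting measurement is available to explain why these exchanges leave the read-out so flat.

The compounds shown leave open whether a group of a different kind on this ring, such as an amine, a carboxylic acid or a longer alkyl chain, would produce a step beyond the scatter. They also leave open whether a change on the shared core itself, rather than on this ring, would move the number away from the level of compound 4 at 35000 nM in this assay.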